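From 3-methoxyphenyl to 4-chlorophenyl on a shared core

This account rests on a few compounds, and the source may have more. Where it says the series, first, only, none or still open, it means among the compounds named here.

Measured compounds in a functional assay on HepG2 cells (Homo sapiens) for antiproliferative activity, read by MTT assay, with a stated time of 72 h; a lower number here means a stronger inhibitor, a higher number a weaker inhibitor:
- Compound 1 `COc1cccc(N2C(=O)COc3ccc(-c4cnc5ccccc5c4)cc32)c1`: 2080 nM
- Compound 2 `O=C1COc2ccc(-c3cnc(Cl)c(NS(=O)(=O)c4ccc(F)cc4)c3)cc2N1`: > 40000 nM (a limit of the assay, not a number)

Within the data shown here, compound 1 holds the only true number in this small set, so it is the natural starting point. Compound 3 `O=C1COc2ccc(-c3cnc4ccccc4c3)cc2N1c1ccc(Cl)cc1` keeps the core of compound 1 and has not yet been measured. It carries 4-chlorophenyl in place of 3-methoxyphenyl on an amide-type nitrogen in a ring. Among the measured compounds shown here, no measured pair of compounds shows what such a swap does. The expectation therefore rests on compound 1 at 2080 nM, and no change beyond the scatter is expected in this assay, with neither direction favoured. The expected step is a 1.2-fold higher number from compound 1 to compound 3 (0.08 log units; within the scatter). For compound 3 the estimated value is 2500 nM, with an expected range from 600 nM to 10000 nM.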

Compound 3, half-maximal inhibitory concentration: 32700 nM
The estimate for compound 3 lay 13-fold (1.12 log units) below the measured number; the whole stated range lies below it.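

In this assay, 4-chlorophenyl in place of 3-methoxyphenyl on the amide-type nitrogen in a ring gives a 16-fold higher number from compound 1 to compound 3 (1.20 log units; beyond the scatter), so the group at this position can change the read-out well beyond the scatter. This one swap alters both the group on the phenyl ring and its numbered place, and the step cannot separate the two changes. Compound 2 is reported only as a limit of the assay, not a number, so no step can be read from it: the limit of > 40000 nM in this assay, at which 1 of the 3 values shown sits.

The compounds shown leave open whether 3-chlorophenyl or 4-methoxyphenyl on the same nitrogen would read closer to compound 1 or to compound 3. Also open, from the compounds shown here alone, is how an unsubstituted phenyl, or a phenyl carrying an amine, would behave at this position in this assay.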